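The compounds below may be only part of what the source reports. "The series", "measured", "known", "first", "only" and "open" are said of these compounds alone.

In a functional assay on K562 cells (Homo sapiens) for cytotoxicity, read by MTT assay, with a stated time of 72 h (on this read-out lower numbers stand for higher toxicity in this test and higher numbers for lower toxicity in this test), two compounds of the shared core have been measured. Compound 1 `C[Se]/C(=N\C(=O)c1cnc2ccccc2c1)NC(=O)c1cnc2ccccc2c1` gives 74800 nM in this assay. Compound 2 `CS/C(=N\C(=O)c1cnc2ccccc2c1)NC(=O)c1cnc2ccccc2c1` is recorded only as a limit of this assay, > 100000 nM, so no number is known for it. For the measured compounds named here, the single measured step, an at least 1.3-fold higher number from compound 1 to compound 2 (0.12 log units; that floor lies within the scatter), is the only guide, and its floor lies within the scatter; the limit of > 100000 nM in this assay, at which 1 of the 2 values shown sits, marks where compound 2 stands. Compound 3 `O=C(/N=C(/NC(=O)c1cnc2ccccc2c1)[Se]Cc1ccccc1)c1cnc2ccccc2c1` differs from compound 2 by a group of 8 heavy atoms (7 carbon, 1 selenium; one six-membered aromatic ring of carbon only) in place of a group of 2 heavy atoms (1 carbon, 1 sulfur; no ring), on a carbon with a double bond to nitrogen. Going by the values given here, this change brings back the selenium of compound 1 and at the same time replaces the methyl by a group carrying one six-membered aromatic ring of carbon only; no measured step covers that added ring. Since the exchange of selenium for sulfur in the step from compound 1 to compound 2 gave no more than a small shift toward lower toxicity, the reverse exchange is expected to give no more than a small shift toward higher toxicity, and the added ring cannot be judged from the data. For compound 3 the expected step is an at least 2.5-fold lower number from compound 2 to compound 3 (0.39 log units; beyond the scatter). Compound 3 is therefore estimated at 40000 nM, with a range from 10000 nM to 100000 nM.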

Compound 3, concentration lethal to 50% of the cells: > 100000 nM
Compound 3: a limit, no number (the forecaster's own chance of this, stated with the estimate: 25%); middle value at least 2.5-fold (0.39 log units) from the limit.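

In this assay compound 3 is recorded only as a limit of the assay, > 100000 nM, and not as a number. With selenium kept, phenyl in place of hydrogen on the saturated chain carbon bound to the selenium atom gives an at least 1.3-fold higher number from compound 1 to compound 3 (0.12 log units; that floor lies within the scatter), so this position on a carbon with a double bond to nitrogen accepts the larger group without any measurable gain in toxicity in this test, though the floor of that step does not separate the two compounds. The step between compound 2 and compound 3 cannot be read, since both values are limits, and the measured compounds now gather at one end of the read-out: the limit of > 100000 nM in this assay, at which 2 of the 3 values shown sit.

The compounds shown leave open how far compound 2 and compound 3 lie past that limit, so neither the exchange of selenium for sulfur nor the added ring has a known size. As far as these compounds go, it also remains open whether another group on the selenium, such as a longer chain or a chain ending in an amine or a carboxylic acid, would give a readable number.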